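Naphthylmethyl in Place of Phenyl on the Macrocycle

The compounds below may be only part of what the source reports. "The series", "measured", "known", "first", "only" and "open" are said of these compounds alone.

Three macrocycles have been measured in an assay on isolated protein for displacement of a labelled ligand from Motilin receptor (Homo sapiens); on this read-out higher numbers stand for weaker inhibition and lower numbers for stronger inhibition. Compound 1 `CCC[C@@H]1NC(=O)[C@@H](C(C)C)NC(=O)[C@@H](Cc2ccc(O)cc2)NCCc2ccccc2CCCCNC1=O` gives 6060 nM, and compound 2 `CCC[C@@H]1NC(=O)[C@@H](C(C)C)NC(=O)[C@@H](Cc2ccc(O)cc2)NCCOc2ccccc2CCCNC1=O` gives 55 nM. Compound 3 `CCC[C@@H]1NC(=O)[C@@H](C(C)C)NC(=O)[C@@H](c2ccccc2)NCCOc2ccccc2CCCNC1=O` reaches only a limit of this assay, > 10000 nM, and no number is known for it. Compound 3 therefore stands at the weak end of the shown values, at the limit described by the limit of > 10000 nM in this assay, at which 1 of the 3 values shown sits. Going by the values given here, the one step that bears on the new compound is an at least 180-fold higher number from compound 2 to compound 3 (2.25 log units; beyond the scatter), a large loss on exchanging 4-hydroxybenzyl for phenyl. Compound 4 `CCC[C@@H]1NC(=O)[C@@H](C(C)C)NC(=O)[C@@H](Cc2ccc3ccccc3c2)NCCOc2ccccc2CCCNC1=O` carries the change ((naphthalen-2-yl)methyl in place of phenyl on a saturated ring carbon), which returns a one-carbon spacer and an aromatic ring system in the position where compound 2 had its 4-hydroxybenzyl group, though without the hydroxyl. Since the step from compound 2 to compound 3 was large, a partial return is expected for compound 4, and its value in this assay is estimated at 800 nM, within 100 nM to 8000 nM, a step of an at least 12-fold lower number from compound 3 to compound 4 (1.09 log units; beyond the scatter) expected toward stronger inhibition.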

Compound 4, inhibition constant: 79 nM
For compound 4 the middle estimate is 10-fold (1.01 log units) above the measured one; measured number outside the range, below it.
By their numbers in this assay, from the lowest: compounds 2 and 4 (each within the scatter of the next); then compound 1. At a limit, above all of these: compound 3.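

In this assay, naphthalen-2-yl in place of 4-hydroxyphenyl on the chain carbon gives a 1.4-fold higher number from compound 2 to compound 4 (0.16 log units; within the scatter), so at this position the compounds shown do not depend on a ring bearing a hydroxyl. (Naphthalen-2-yl)methyl in place of phenyl on the saturated ring carbon gives an at least 120-fold lower number from compound 3 to compound 4 (2.10 log units; beyond the scatter), which shows that the loss in compound 3 does not follow from the absence of the hydroxyl alone. Compound 3 is held only by a limit, so this step is a bound and not a measured distance: the limit of > 10000 nM in this assay, at which 1 of the 4 values shown sits.

The change brings in both a one-carbon spacer and a second aromatic ring, and the compounds shown cannot tell these two apart; a plain benzyl group on this carbon would separate them. Going by these compounds, how an amine or a carboxylic acid on the aromatic ring would fare also remains open.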